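Carbonyl substituent variation and cytotoxicity on the shared core

A few compounds are considered here, and "the series" means these few. Any claim that something is new, unique, unknown or untested is made for them only; others in the source may bear on it.

Measured so far:
compound 1 `C=CC1=C(C(=O)NCc2ccc(C)cc2)C(c2ccc(OC)c(OC)c2)OC1`: > 100000 nM
compound 2 `C=CC1=C(C(=O)O)C(c2ccc(OC)c(OC)c2)OC1`: > 100000 nM

Compound 1 gives in a functional assay on A549 cells (Homo sapiens) for cytotoxicity, read by MTT assay, with a stated time of 24 h (on this read-out lower numbers stand for stronger inhibition and higher numbers for weaker inhibition), only a limit of the assay, > 100000 nM. Compound 2 likewise returns only a limit in this assay, > 100000 nM. Among the measured compounds shown here, the one step between measured compounds, a step that the two limits leave unreadable from compound 1 to compound 2, is therefore unreadable, since both values sit at the limit of > 100000 nM in this assay, at which 2 of the 2 values shown sit. Compound 2 thus stands at the limit of the assay, with no number to separate it from compound 1.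

Compound 3 `C=CC1=C(C(=O)Nc2ccccc2)C(c2ccc(OC)c(OC)c2)OC1` is the next variant on the same carbonyl carbon: anilino in place of hydroxy on a carbonyl carbon. For the measured compounds named here, the only measured step bearing on it is the change of the group on this carbonyl carbon, and its size could not be read. Going by the values given here, no measured step gives a direction for the present change. The expectation for compound 3 is that it stays at the limit as well, so the step of a number no higher from compound 2 to compound 3 (the limit leaves the size open) is estimated as none beyond the scatter. Compound 3 is therefore estimated at 100000 nM, with a range of 30000 nM to 300000 nM.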

Compound 3, half-maximal inhibitory concentration: > 100000 nM
Compound 3 ended at the assay's limit; the forecaster's own chance of this, stated with the estimate: 80%; the middle value lies on the limit itself.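

No new step can be read: the steps among compound 1, compound 2 and compound 3 all stay unreadable, since all three values are the same limit: the limit of > 100000 nM in this assay, at which 3 of the 3 values shown sit.

The compounds shown leave open how far each lies from that limit, and whether any group on this carbonyl carbon alters the cytotoxicity read-out.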